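The source may hold more compounds than are shown below. What is called first, only, known or untested is meant among the compounds shown, and "the series" means these compounds.

Working notes on the series. Compound 3 `CCOC(=O)c1cnn(-c2nc(-c3cccc(OC)c3OC)c(C#N)c(=O)n2C)c1N` gives 67 ug/mL in a functional assay, with a stated time of 10 min; a higher number here means a weaker inhibitor, a lower number a stronger inhibitor. Compound 1 `CCOC(=O)c1cnn(-c2nc(-c3ccc(OC)cc3)c(C#N)c(=O)n2C)c1N` gives 74 ug/mL in this assay, and compound 2 `CCOC(=O)c1cnn(-c2nc(-c3ccccc3F)c(C#N)c(=O)n2C)c1N` gives 86 ug/mL. Compound 3 holds the lowest of the three numbers, yet its gaps to both neighbours lie within the scatter: a 1.1-fold lower number from compound 1 to compound 3 (0.04 log units; within the scatter) and a 1.3-fold lower number from compound 2 to compound 3 (0.11 log units; within the scatter). The remaining pair is no different, a 1.2-fold higher number from compound 1 to compound 2 (0.07 log units; within the scatter).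

Compound 4 `CCOC(=O)c1cnn(-c2nc(-c3ccccc3O)c(C#N)c(=O)n2C)c1N` is not yet measured. The change from compound 3 is 2-hydroxyphenyl in place of 2,3-dimethoxyphenyl on an aromatic carbon. All three measured steps are swaps of the aryl group at this same place, and none moved the number beyond the scatter, so a further aryl swap is expected to do the same. For the measured compounds named here, no measured compound carries a hydrogen-bond donor on this aryl group, which leaves the range somewhat open. Compound 4 is therefore expected to show a 1.0-fold higher number from compound 3 to compound 4 (0.02 log units; within the scatter). Compound 4 is estimated at 70 ug/mL in this assay, with a range from 35 ug/mL to 150 ug/mL.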

Compound 4, half-maximal inhibitory concentration: 58 ug/mL
Beside the measured number, compound 4's estimate is 1.2-fold (0.08 log units) above it; measured number inside the range.
By their numbers in this assay, from the lowest: compounds 4, 3, 1 and 2 (each within the scatter of the next).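

In this assay, for the compounds shown here, compound 4 brings a hydrogen-bond donor onto this aryl group for the first time, yet every step to it stays within the scatter: a 1.2-fold lower number from compound 3 to compound 4 (0.06 log units; within the scatter), a 1.5-fold lower number from compound 2 to compound 4 (0.17 log units; within the scatter) and a 1.3-fold lower number from compound 1 to compound 4 (0.11 log units; within the scatter). At this position, on the aromatic carbon ortho to the cyano group, the number therefore tolerates a hydroxy in place of fluoro as well as the loss of heavy atoms on going from 2,3-dimethoxyphenyl to 2-hydroxyphenyl. No supporting data bear on why these steps are so small.

From the compounds shown here alone, whether any group at this position can move the number beyond the scatter remains open, for example an aryl group carrying an amine or a carboxylic acid, or a longer alkyl chain in place of the aryl group. The ethyl ester and the nitrile are the same in all four compounds, so their contribution cannot be read from this set.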